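Chloro for hydrogen on the fused ring, second pair

The compounds below may be only part of what the source reports. "The series", "measured", "known", "first", "only" and "open" are said of these compounds alone.

Compound 1 `Cc1cnc(Nc2ccc(S(C)(=O)=O)cc2)nc1Nc1nc2ccc(Cl)cc2s1` and compound 2 `Cc1cnc(Nc2ccc(S(C)(=O)=O)cc2)nc1Nc1nc2ccccc2s1` share one core and differ only by chloro in place of hydrogen on an aromatic carbon. In a functional assay on MCF7 cells (Homo sapiens) for antiproliferative activity, read by MTT assay, with a stated time of 48 h (a lower number here means a stronger inhibitor, a higher number a weaker inhibitor), compound 2 gives 6550 nM. In the same assay compound 1 gives 4320 nM. The step of a 1.5-fold lower number from compound 2 to compound 1 (0.18 log units; within the scatter) is small and within the scatter, so the two values show no order between them.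

Compound 3 `NS(=O)(=O)c1ccc(Nc2ncc(F)c(Nc3nc4ccccc4s3)n2)cc1` carries a different core; the difference between the two cores is not broken down here. In this assay compound 3 reaches only the limit of the measurement and gives > 50000 nM. That is the limit of > 50000 nM in this assay, at which 1 of the 3 values shown sits, and no number stands behind it.

Compound 4 `NS(=O)(=O)c1ccc(Nc2ncc(F)c(Nc3nc4ccc(Cl)cc4s3)n2)cc1` has not yet been measured in this assay. It differs from compound 3 by chloro in place of hydrogen on an aromatic carbon, the same change as that made between compound 2 and compound 1, at a place described in the same words. For compound 4 the expected step is a step that the limit leaves unreadable from compound 3 to compound 4, in line with the small step of a 1.5-fold lower number from compound 2 to compound 1 (0.18 log units; within the scatter) seen for the first pair, and that pair is the only ground for the expectation. The expected value for compound 4 is 55000 nM, with a range from 20000 nM to 150000 nM, and the assay is expected again to report only a limit rather than a number.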

Compound 4, half-maximal inhibitory concentration: 8340 nM
The estimate for compound 4 lay 6.6-fold (0.82 log units) above the measured number; measured number below the stated range.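

In this assay, chloro in place of hydrogen on the fused ring gives an at least 5.9-fold lower number from compound 3 to compound 4 (0.77 log units; beyond the scatter), so on the core of compound 3 the change goes with a clear shift to a lower number, and the same change does not carry over at one size from the core of compound 1: the same change on two cores in this assay, a 1.5-fold lower number (0.18 log units; within the scatter) from compound 2 to compound 1 and an at least 5.9-fold lower number (0.77 log units; beyond the scatter) from compound 3 to compound 4, at least 3.9-fold (0.59 log units) apart, beyond the scatter of two such steps. Compound 3 has only a limit, so the step on its core has a lower bound and no exact size: the limit of > 50000 nM in this assay, at which 1 of the 4 values shown sits. The two cores are not broken down here, so the gap between the steps cannot be tied to any one part of them, and two pairs give no rule for a third core.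

Open, from the compounds shown here alone, is how bromo, methoxy or a nitrile on the same aromatic carbon would read on either core. For the compounds shown here, also open is whether the larger step follows the sulfonamide or the fluoro of the core of compound 3, which a compound holding only one of those two groups would separate.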